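Urea in place of acrylamide at the aryl amine

The source may report more compounds than this note shows. Statements on the series, on what has been measured and on what is new or still open speak of the compounds shown alone.

Compound 3 `C=CC(=O)Nc1ccc(-c2cc(=O)c3c(O)cc(OC)c(OC(C)C)c3o2)cc1` gives 5800 nM in a functional assay on CWR22R cells (Homo sapiens) for antiproliferative activity, read by MTT assay, with a stated time of 3 days; a higher number here means a weaker inhibitor, a lower number a stronger inhibitor. Among the three compounds measured, compound 3 holds the second highest number: its nearest neighbour, compound 1 `CCCS(=O)(=O)Nc1ccc(-c2cc(=O)c3c(O)cc(OC)c(OC(C)C)c3o2)cc1`, gives 2900 nM, a gap within the scatter, while compound 2 `COc1cc(O)c2c(=O)cc(-c3ccc(NS(=O)(=O)C4CC4)cc3)oc2c1OC(C)C` gives 19700 nM, the furthest of the set.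

Compound 4 `COc1cc(O)c2c(=O)cc(-c3ccc(NC(=O)N4CCN(C)CC4)cc3)oc2c1OC(C)C` differs from compound 3 in one place: 4-methylpiperazin-1-yl in place of vinyl on a carbonyl carbon.

The steps seen so far all alter the group on the same aryl nitrogen. The step of a 2.0-fold higher number from compound 1 to compound 3 (0.30 log units; within the scatter) lay within the scatter, the step of a 3.4-fold lower number from compound 2 to compound 3 (0.53 log units; beyond the scatter) was modest, and the step of a 6.8-fold higher number from compound 1 to compound 2 (0.83 log units; beyond the scatter) was the largest of the three. Going by the values given here, no measured pair carries a urea or a piperazine, so there is no direct precedent for this change. Since replacements on this nitrogen have so far moved this assay only modestly, the expected step is a 1.2-fold higher number from compound 3 to compound 4 (0.08 log units; within the scatter), with no change beyond the scatter the most likely outcome. Compound 4 is therefore estimated at 7000 nM, with a range from 2000 nM to 25000 nM.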

Compound 4, half-maximal inhibitory concentration: 8800 nM
For compound 4 the middle estimate is 1.3-fold (0.10 log units) below the measured one; measured number inside the range.
By their numbers in this assay, from the lowest: compounds 1, 3 and 4 (each within the scatter of the next, the first and the last beyond it); then compound 2.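

In this assay, the vinyl of the acrylamide gives way to the much larger 4-methylpiperazin-1-yl, with its six-membered ring, and the change stays within the scatter (a 1.5-fold higher number from compound 3 to compound 4 (0.18 log units; within the scatter)). This shows that the carbonyl carbon on the aryl nitrogen accepts a urea as well as an acrylamide in this assay. Set against the two sulfonyl compounds, the urea falls between them, with modest steps in opposite directions (a 2.2-fold lower number from compound 2 to compound 4 (0.35 log units; beyond the scatter)) and (a 3.0-fold higher number from compound 1 to compound 4 (0.48 log units; beyond the scatter)), and nothing available explains these steps.

From the compounds shown here alone, it remains open whether the methyl on the piperazine matters to this reading. A morpholine or a dimethylamino group on the same carbonyl carbon would test whether the second ring nitrogen or the ring itself counts in this assay.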